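Swapping the amide-side benzyl group in a bromo-naphthyridine amide

The source may report more compounds than this note shows. Statements on the series, on what has been measured and on what is new or still open speak of the compounds shown alone.

Measured compounds:
compound 1, `CC(C)(C)OC(=O)N1CCN(c2c(C(=O)NCc3ccc(F)cc3)nc(Br)c3cccnc23)CC1`: > 10000 nM
compound 2, `COc1cccc(CNC(=O)c2nc(Br)c3cccnc3c2N[C@H]2CC[C@H](N)CC2)c1`: 6000 nM

In a functional assay on HCT-116 cells (Homo sapiens) for cytotoxicity, read by MTT assay, with a stated time of 72 h (on this read-out higher numbers stand for weaker inhibition and lower numbers for stronger inhibition), compound 1 reaches only a limit, > 10000 nM, so no number is known for it. Compound 2, which carries a 3-methoxybenzyl group on its amide nitrogen and an amino-cyclohexyl amine on the shared core, gives 6000 nM in this assay. Within the data shown here, compound 2 is therefore the only compound here with an actual number. The value of compound 1 is a limit (the limit of > 10000 nM in this assay, at which 1 of the 2 values shown sits).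

Compound 3, `C[C@H](NC(=O)c1nc(Br)c2cccnc2c1N[C@H]1CC[C@H](N)CC1)c1ccc(F)cc1`, keeps the whole of compound 2 except for one group: 1-(4-fluorophenyl)ethyl in place of 3-methoxybenzyl on an amide-type nitrogen. Among the measured compounds shown here, no pair of measured compounds differing in a single place is available, so the size of this step cannot be read from the data. The step of a 1.3-fold lower number from compound 2 to compound 3 (0.12 log units; within the scatter) is expected to be modest, most likely no larger than the scatter of repeated measurements, with no clear direction. Compound 3 is thus estimated at 4500 nM in this assay, within a range from 1500 nM to 15000 nM.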

Compound 3, half-maximal inhibitory concentration: > 10000 nM
Compound 3 was reported as a limit (the forecaster's own chance of this, stated with the estimate: 25%); middle value at least 2.2-fold (0.34 log units) away from the limit.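

Among these compounds, for the first time, two compounds that differ in only one place can be compared, and that place is an amide-type nitrogen. In this assay, putting 1-(4-fluorophenyl)ethyl in place of 3-methoxybenzyl gives an at least 1.6-fold higher number from compound 2 to compound 3 (0.22 log units; that floor lies within the scatter), so this exchange offers no sign of stronger inhibition, although the smallest step the data allow does not clear the usual scatter. The real size of the step stays unknown, because compound 3 reaches only a limit of the assay, as compound 1 does: the limit of > 10000 nM in this assay, at which 2 of the 3 values shown sit.

This single exchange alters two things at once, since a methoxy group gives way to fluorine and a defined stereocentre enters, and the compounds shown cannot separate those two changes. A 4-fluorobenzyl group on this same amide-type nitrogen, with the amino-cyclohexyl amine kept in place, would speak to the fluorine alone, while the mirror-image 1-(4-fluorophenyl)ethyl group would speak to the stereocentre, and neither is among the compounds shown.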